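Piperazine for Piperidine on a Weakly Active Core

The compounds below may be only part of what the source reports. "The series", "measured", "known", "first", "only" and "open" are said of these compounds alone.

Compound 2 `Cc1cc(N2CCCCC2)nc(SCc2nc3ccccc3[nH]2)n1` was run in a functional assay on MGC-803 cells (Homo sapiens) for cytotoxicity, read by MTT assay, with a stated time of 72 h; on this read-out higher numbers stand for weaker inhibition and lower numbers for stronger inhibition. In this assay compound 2 gives only a limit, > 100000 nM, so no exact number is known for it. Compound 1 `COc1ccc(Nc2cc(C)nc(SCc3nc4ccccc4[nH]3)n2)cc1` gives 51100 nM in this assay. The step of an at least 1.9-fold higher number from compound 1 to compound 2 (0.29 log units; that floor lies within the scatter) rests on (the limit of > 100000 nM in this assay, at which 1 of the 2 values shown sits). Compound 3 `Cc1cc(N2CCNCC2)nc(SCc2nc3ccccc3[nH]2)n1` carries piperazin-1-yl in place of piperidin-1-yl on an aromatic carbon. Among the measured compounds shown here, no measured step covers this exchange, and the only measured step is the one above, which leaves compound 2 at the limit. Compound 3 is therefore expected near 100000 nM, between 30000 nM and 300000 nM, an expected step of a number no higher from compound 2 to compound 3 (the limit leaves the size open) that stays within the scatter.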

Compound 3, half-maximal inhibitory concentration: > 100000 nM
Compound 3 was reported as a limit (the forecaster's own chance of this, stated with the estimate: 60%); the middle value lies on the limit itself.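

Putting piperazin-1-yl on this aromatic carbon in place of piperidin-1-yl still gives no exact number in this assay, so the second ring nitrogen does not bring this position into the readable range. Among the compounds shown here, the step between compound 2 and compound 3 cannot be read because both values are limits: the limit of > 100000 nM in this assay, at which 2 of the 3 values shown sit. The one readable step is an at least 1.9-fold higher number from compound 1 to compound 3 (0.29 log units; that floor lies within the scatter), so it gives no firm separation either.

On these data alone, whether morpholin-4-yl or 4-methylpiperazin-1-yl on this carbon would give an exact value stays open.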